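Aryl swap on the imine carbon of the spirocyclic core

The compounds below may be only part of what the source reports. "The series", "measured", "known", "first", "only" and "open" are said of these compounds alone.

Measured compounds:
Compound 1 `C[C@H](c1ccc(C(=O)NCCC(=O)O)cc1)N1C(=O)C(c2ccc(F)cc2)=N[C@]12CC[C@@H](C(C)(C)C)CC2`: in an assay on CHO cells for displacement of a labelled ligand from Glucagon receptor (Homo sapiens), read by scintillation counting, with a stated time of 60 min (on this read-out lower numbers stand for stronger inhibition and higher numbers for weaker inhibition), compound 1 gives 85 nM.
Compound 2 `C[C@H](c1ccc(C(=O)NCCC(=O)O)cc1)N1C(=O)C(c2cccc(Cl)c2)=N[C@]12CC[C@@H](C(C)(C)C)CC2`: in this assay compound 2 gives 130 nM.

Among the measured compounds shown here, compound 2 stands at the higher of the two numbers, but the only measured step, a 1.5-fold higher number from compound 1 to compound 2 (0.18 log units; within the scatter), falls within the scatter, so the two compounds are not separated. Compound 3 `C[C@H](c1ccc(C(=O)NCCC(=O)O)cc1)N1C(=O)C(c2ccccc2F)=N[C@]12CC[C@@H](C(C)(C)C)CC2` differs from compound 2 by 2-fluorophenyl in place of 3-chlorophenyl on a carbon with a double bond to nitrogen. For the measured compounds named here, no measured step covers a 2-fluorophenyl at this position; the one step that touches this aryl group was small. The change is therefore expected to give no step beyond the scatter, a 1.2-fold lower number from compound 2 to compound 3 (0.07 log units; within the scatter). For compound 3 the estimate in this assay is 110 nM, with a range from 45 nM to 270 nM.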

Compound 3, half-maximal inhibitory concentration: 1100 nM
The estimate for compound 3 lay 10-fold (1.00 log units) below the measured number, and the stated range ends below it.
By their numbers in this assay, from the lowest: compounds 1 and 2 (each within the scatter of the next); then compound 3.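

Placing 2-fluorophenyl on the carbon with a double bond to nitrogen gives the first step beyond the scatter at this position in this assay, both in place of 3-chlorophenyl (an 8.5-fold higher number from compound 2 to compound 3 (0.93 log units; beyond the scatter)) and in place of 4-fluorophenyl (a 13-fold higher number from compound 1 to compound 3 (1.11 log units; beyond the scatter)). The position therefore does respond to the choice of aryl group, although compounds 1 and 2 were not separated. Nothing available bears on the reason for these steps.

Compounds 1, 2 and 3 vary the ring substituent and its place together, so the two effects cannot be separated. Open, as far as these compounds go, is how a plain phenyl, or a chlorine or methoxy group where 2-fluorophenyl carries its fluorine, would compare.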